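The compounds below may be only part of what the source reports. "The series", "measured", "known", "first", "only" and "open" are said of these compounds alone.

Three compounds that share one core and differ only in the aryl group on an amine nitrogen in a ring have been tested in a functional assay on HL-60 cells (Homo sapiens) for inhibition, read by MTT assay, with a stated time of 72 h; a higher number here means a weaker inhibitor, a lower number a stronger inhibitor. Compound 1 `Cc1nc(-c2ccccc2)c(C(=O)N2CCN(c3cccc(Cl)c3)CC2)o1` gives 39.2 nM, and compound 2 `Cc1nc(-c2ccccc2)c(C(=O)N2CCN(c3ccccc3C(F)(F)F)CC2)o1` gives 120 nM. Compound 3 `Cc1nc(-c2ccccc2)c(C(=O)N2CCN(c3c(C)cccc3C)CC2)o1` gives 146 nM, the highest of the three numbers, although its gap to the nearest value is small: a 1.2-fold higher number from compound 2 to compound 3 (0.09 log units; within the scatter). The gap to the furthest value is larger: a 3.7-fold higher number from compound 1 to compound 3 (0.57 log units; beyond the scatter).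

Compound 4 `Cc1nc(-c2ccccc2)c(C(=O)N2CCN(c3cccc(C(F)(F)F)c3)CC2)o1` has not yet been measured. It carries 3-(trifluoromethyl)phenyl in place of 2,6-dimethylphenyl on an amine nitrogen in a ring.

Going by the values given here, no measured compound carries this exact group, so the expectation rests on two neighbouring steps. Compound 1, with 3-chlorophenyl, has the closest name to the entering group, and the step to compound 3 is modest at a 3.7-fold higher number from compound 1 to compound 3 (0.57 log units; beyond the scatter). Compound 2 holds the trifluoromethyl group within 2-(trifluoromethyl)phenyl, and the step to it is also modest: a 3.1-fold higher number from compound 1 to compound 2 (0.49 log units; beyond the scatter). A modest move toward a lower number therefore seems likely, and the estimated step is a 2.7-fold lower number from compound 3 to compound 4 (0.42 log units; beyond the scatter). For compound 4 the expected value is 55 nM, with an estimated range of 22 nM to 130 nM.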

Compound 4, half-maximal inhibitory concentration: 153 nM
Beside the measured number, compound 4's estimate is 2.8-fold (0.44 log units) below it; measured number outside the range, above it.
By their numbers in this assay, from the lowest: compound 1; then compounds 2, 3 and 4 (each within the scatter of the next).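

In this assay, going by these compounds alone, the new compound separates the place of the substituent on the phenyl ring from its identity, which the earlier compounds could not do. With trifluoromethyl on the same aromatic carbon that bears chloro in compound 1, the step is a 3.9-fold higher number from compound 1 to compound 4 (0.59 log units; beyond the scatter), so 3-substitution alone does not preserve the low number of compound 1, and among these two compounds the exchange of chloro for trifluoromethyl is what matters. Moving the trifluoromethyl group from 2-(trifluoromethyl)phenyl to 3-(trifluoromethyl)phenyl gives a 1.3-fold higher number from compound 2 to compound 4 (0.11 log units; within the scatter), and replacing 2,6-dimethylphenyl gives a 1.0-fold higher number from compound 3 to compound 4 (0.02 log units; within the scatter), so compounds 2, 3 and 4 cannot be told apart here and compound 1 alone stands away from them.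

The compounds shown leave open whether bromo, fluoro, methyl or methoxy on that aromatic carbon would track with chloro or with trifluoromethyl, and whether chloro would hold its value on another carbon of the phenyl ring. No supporting measurement is available to explain the difference between chloro and trifluoromethyl.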